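The compounds below may be only part of what the source reports. "The series", "measured", "known", "first", "only" and "open" are said of these compounds alone.

Measured so far in an ADME assay on HEp-2 cells (Homo sapiens) for cytotoxicity, with a stated time of 4 days; on this read-out higher numbers stand for lower toxicity in this test and lower numbers for higher toxicity in this test:
compound 1, `CS(=O)(=O)CCn1c(Cn2cc(S(C)(=O)=O)c3ccccc32)nc2cc(Cl)ccc21`: > 100000 nM
compound 2, `CC(C)(O)CCn1c(Cn2nc(S(C)(=O)=O)c3ccncc32)nc2cc(Cl)ccc21`: > 100000 nM

Compound 2 stands at the edge of what this assay can report: its value of > 100000 nM is a limit of the assay, not a number. Compound 1 likewise returns only a limit, at > 100000 nM. Among the compounds with values here, the two measured compounds thus both sit at the limit of > 100000 nM in this assay, at which 2 of the 2 values shown sit, and no step between measured compounds can be computed from them.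

Compound 3, `CS(=O)(=O)c1nn(Cc2nc3cc(Cl)ccc3n2CCCCC(F)(F)F)c2cnccc12`, is not yet measured. It differs from compound 2 in one place:
3,3,3-trifluoropropyl in place of 1-hydroxy-1-methylethyl on a saturated chain carbon, two bonds along the chain from an aromatic nitrogen

Within the data shown here, since both measured compounds give only limits, no size of step in this assay can be read from the data for such a change. The step from compound 2 to compound 3 is therefore expected to be a number no higher from compound 2 to compound 3 (the limit leaves the size open), which is no step beyond the scatter. Compound 3 is expected to give about 100000 nM, in the range 30000 nM to 300000 nM, most likely again as a limit.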

Compound 3, half-maximal cytotoxic concentration: > 100000 nM
Compound 3: no number, only a limit (the forecaster's own chance of this, stated with the estimate: 75%); the middle value lies on the limit itself.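

No step can be read from compound 2 to compound 3 in this assay, as both give only a limit of the assay and not a number: the limit of > 100000 nM in this assay, at which 3 of the 3 values shown sit.

The compounds shown leave open how far any of them lies beyond that limit, and whether the change from 1-hydroxy-1-methylethyl to 3,3,3-trifluoropropyl shifts the read-out at all.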